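Adding a second methoxy to a thiophene-fused ester

The source may hold more compounds than are shown below. What is called first, only, known or untested is meant among the compounds shown, and "the series" means these compounds.

Three compounds share one core. Compound 1 `CCOC(=O)[C@@H]1CC(=O)c2sccc2[C@H]1c1ccc(OC)cc1` carries a methoxy on its phenyl ring, compound 2 `CCOC(=O)[C@@H]1CC(=O)c2sccc2[C@H]1c1ccc(OCC)cc1` an ethoxy, and compound 3 `CCOC(=O)[C@@H]1CC(=O)c2sccc2[C@H]1c1ccccc1OC` a methoxy at another spot. In a physicochemical assay, with a stated time of 60 min, tested at 80 ug/mL (a lower number here means a weaker effect, a higher number a stronger effect of the compound at the concentration tested), compound 1 gives 31%, compound 2 gives 34.1% and compound 3 gives 29.8%; all three lie within the scatter of one another, so compound 3 is neither weaker nor stronger than the others on these numbers.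

Compound 4 `CCOC(=O)[C@@H]1CC(=O)c2sccc2[C@H]1c1ccc(OC)cc1OC` differs from compound 3 in one place: methoxy in place of hydrogen on an aromatic carbon. For the measured compounds named here, no measured step adds a methoxy to the ring. Going by the values given here, the only measured step, a number 3.1 percentage points higher from compound 1 to compound 2 (within the scatter), enlarges an alkoxy group and stays within the scatter, and compounds 1 and 3, which carry their single methoxy at different places, show values within the scatter of each other. On this basis the step of a number 1.2 percentage points higher from compound 3 to compound 4 (within the scatter) is expected to remain within the scatter. Compound 4 is therefore estimated to give 31%, with a range from 20% to 42%.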

Compound 4, a percentage reported as activity, at one concentration (the size of the read-out at that concentration, not a potency): 23.9%
The estimate for compound 4 lay 7.1 percentage points above the measured number; the range from low to high includes it.
By their numbers in this assay, from the lowest: compounds 4, 3, 1 and 2 (each within the scatter of the next, the first and the last beyond it).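

Adding a methoxy to an aromatic carbon of the six-membered ring can now be read twice in this assay: one addition gives a number 5.9 percentage points lower from compound 3 to compound 4 (within the scatter), and the other gives a number 7.1 percentage points lower from compound 1 to compound 4 (within the scatter). Both steps stay within the scatter, so on these numbers a second methoxy shows no clear effect on the read-out, whichever single-methoxy compound it is added to. Nothing available here explains these numbers.

The compounds shown carry only methoxy and ethoxy groups on this ring, so it remains open whether an amine or a carboxylic acid in the place of the added methoxy would stay within the scatter. A longer chain on the oxygen of that added group also remains an open question.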